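Changing the amide side chain of compound 2

A few compounds are considered here, and "the series" means these few. Any claim that something is new, unique, unknown or untested is made for them only; others in the source may bear on it.

Among the measured compounds shown here, in an ADME assay on L02 cells (Homo sapiens) for antiproliferative activity, read by MTT assay, with a stated time of 48 h (on this read-out lower numbers stand for stronger inhibition and higher numbers for weaker inhibition), compound 1 `CCC(C)C(NC(=O)c1ccc(C(CC)(CC)c2ccc(OCCC(O)(CC)CC)c(C)c2)n1CC)C(=O)O` gives 9990 nM and compound 2 `CCn1c(C(=O)N(C)CC(=O)O)ccc1C(CC)(CC)c1ccc(OCCC(O)(CC)CC)c(C)c1` gives 2150 nM, which is the lower of the two numbers so far. Compound 3 `CCn1c(C(=O)NC(CC(=O)O)C(=O)OC)ccc1C(CC)(CC)c1ccc(OCCC(O)(CC)CC)c(C)c1` keeps the shared core and differs from compound 2 only in the group on a carbonyl carbon: a group of 10 heavy atoms (5 carbon, 1 nitrogen, 4 oxygen; no ring) in place of a group of 6 heavy atoms (3 carbon, 1 nitrogen, 2 oxygen; no ring), on a carbonyl carbon.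

For the measured compounds named here, one measured step bears on this change, since it falls at the same place: a 4.6-fold lower number from compound 1 to compound 2 (0.67 log units; beyond the scatter). That step shows that this group can shift the number by a modest amount, but it is a single step and a different swap, so it offers only a rough guide. Compound 3 carries an amide hydrogen, as compound 1 does, whereas compound 2 has none. Compound 3 is therefore expected to lie between compound 2 and compound 1, or close to them, in this assay. The expected change is modest and towards a higher number: a 2.1-fold higher number from compound 2 to compound 3 (0.32 log units; beyond the scatter). Compound 3 is estimated at 4500 nM, with an expected range from 1500 nM to 14000 nM.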

Compound 3, half-maximal inhibitory concentration: 7590 nM
Estimate against measurement, compound 3: 1.7-fold (0.23 log units) below; low and high end bracket the measured number.
By their numbers in this assay, from the lowest: compound 2; then compounds 3 and 1 (each within the scatter of the next).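

In this assay, this change gives a 3.5-fold higher number from compound 2 to compound 3 (0.55 log units; beyond the scatter), so compound 3 is a second side chain, after that of compound 1, that stands at a clearly higher number than the (carboxymethyl)(methyl)amino group of compound 2. Comparing the two side chains that carry the amide hydrogen gives a 1.3-fold lower number from compound 1 to compound 3 (0.12 log units; within the scatter), so these two groups cannot be told apart in this assay, even though they differ in their atoms. Of these three compounds, compound 2 alone lacks the amide hydrogen and has the lowest number, and neither of the others goes against that link, but compound 2 also has the smallest group, so the two features cannot be separated.

On these data alone, what remains open is whether placing a methyl on the amide nitrogen of compound 3 would bring its number down towards that of compound 2, which would test the amide hydrogen directly. As far as these compounds go, it is also open how a longer chain ending in a carboxylic acid, or a group ending in an amine, would behave on this carbonyl carbon.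

No measurement of another kind is available to explain these differences.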